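Aryl swap on the acetoxy core: quinolinyl to isoquinolinyl

The source may report more compounds than this note shows. Statements on the series, on what has been measured and on what is new or still open speak of the compounds shown alone.

Compound 1 `CC(=O)OC1=C(c2cccc3cccnc23)Oc2cc3ccccc3cc2-n2cccc21` carries an acetoxy group on the shared core and a quinolin-8-yl group on the double-bonded ring carbon. In an ADME assay on NIH3T3 cells (Mus musculus) for cytotoxicity, read by MTT assay, with a stated time of 48 h (on this read-out lower numbers stand for stronger inhibition and higher numbers for weaker inhibition), compound 1 gives 34 nM, the lowest of the two numbers in hand. Among the compounds with values here, the only other measured member is compound 2 `CCN(CC)CCCC(C)NC(=O)OC1=C(c2cccc3cccnc23)Oc2cc3ccccc3cc2-n2cccc21`, which in this assay gives 2300 nM; the step of a 68-fold higher number from compound 1 to compound 2 (1.83 log units; beyond the scatter) is large and concerns the (4-(diethylamino)-1-methylbutyl)amino group in place of methyl on a carbonyl carbon, leaving the aryl group untouched.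

Compound 3 `CC(=O)OC1=C(c2cccc3cnccc23)Oc2cc3ccccc3cc2-n2cccc21` keeps the acetoxy group and differs from compound 1 only by isoquinolin-5-yl in place of quinolin-8-yl on a double-bonded ring carbon. Within the data shown here, no measured step touches this part of the molecule, so the one step in hand, from compound 1 to compound 2, does not bear on the change, and there is no basis for expecting a shift beyond the scatter. Compound 3 is therefore expected to sit close to compound 1, with an estimated step of a 1.5-fold higher number from compound 1 to compound 3 (0.17 log units; within the scatter). The estimate for compound 3 in this assay is 50 nM, between 15 nM and 200 nM.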

Compound 3, half-maximal inhibitory concentration: 375 nM
For compound 3 the middle estimate is 7.5-fold (0.88 log units) below the measured one; the whole stated range lies below it.
By their numbers in this assay, from the lowest: compound 1; then compound 3; then compound 2.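

In this assay, the aryl group on the double-bonded ring carbon next to the ring oxygen proves sensitive to the arrangement of its atoms: swapping quinolin-8-yl for isoquinolin-5-yl gives an 11-fold higher number from compound 1 to compound 3 (1.04 log units; beyond the scatter), although the two groups match in heavy atoms, ring types, hydrogen-bond donors and hydrogen-bond acceptors. The earlier step involved only the group on the carbonyl carbon, whereas this one shows that the number also moves with the acetoxy group held fixed and only the aryl group changed. Nothing at hand explains the size of this step.

On these data alone, it remains open whether the swap to isoquinolin-5-yl would give a step of similar size with the (4-(diethylamino)-1-methylbutyl)amino group in place of methyl on the carbonyl carbon. The compounds shown also leave open how a phenyl group at this position would compare with quinolin-8-yl, and so whether the ring nitrogen of the aryl group matters at all.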